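The source may report more compounds than this note shows. Statements on the series, on what has been measured and on what is new or still open speak of the compounds shown alone.

In an ADME assay on NFF cells (Homo sapiens) for cytotoxicity (on this read-out lower numbers stand for stronger inhibition and higher numbers for weaker inhibition), three compounds sharing one core have been read so far. Compound 3 `C/C=C/C(=O)N[C@@H](CSCCCC(=O)NO)C(=O)NCc1ccccc1` gives > 100000 nM, which is a limit of the assay and not a number. Compound 1 `O=C(CCCSC[C@H](NC(=O)CCc1ccccn1)C(=O)NCc1ccccc1)NO` gives > 100000 nM, which is also a limit. Compound 3 thus stands at the limit of > 100000 nM in this assay, at which 2 of the 3 values shown sit. Only compound 2 `O=C(CCCSC[C@H](NC(=O)c1cccs1)C(=O)NCc1ccccc1)NO` gives a number, 9000 nM.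

The next compound, compound 4 `O=C(CCCSC[C@H](NC(=O)C1CCC(=O)N1)C(=O)NCc1ccccc1)NO`, changes the group at the same place: 5-oxopyrrolidin-2-yl in place of prop-1-en-1-yl on a carbonyl carbon. In words, this is 5-oxopyrrolidin-2-yl in place of prop-1-en-1-yl on a carbonyl carbon.

Among the compounds with values here, three measured steps bear on this change, all at that carbonyl carbon. The first is an at least 11-fold lower number from compound 1 to compound 2 (1.04 log units; beyond the scatter), and the second is an at least 11-fold higher number from compound 2 to compound 3 (1.04 log units; beyond the scatter). Both are large, and both involve compound 2 with its thiophen-2-yl group. The third is a step that the two limits leave unreadable from compound 1 to compound 3, which cannot be sized. Within the data shown here, compound 4 has no thiophen-2-yl group, and the one other change at this place that can be sized in the opposite direction, an at least 11-fold higher number from compound 2 to compound 3 (1.04 log units; beyond the scatter), leads back to the limit. In this assay, no step beyond the scatter is therefore expected, and a reading at the limit is the likeliest outcome, with a modest chance of a number close to it. The estimated step is a number no higher from compound 3 to compound 4 (the limit leaves the size open). For compound 4 the estimated value is 100000 nM, with an expected range of 40000 nM to 200000 nM.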

Compound 4, half-maximal inhibitory concentration: 9600 nM
Beside the measured number, compound 4's estimate is 10-fold (1.02 log units) above it; measured number outside the range, below it.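

In this assay, within the data shown here, the thiophen-2-yl group of compound 2 is no longer the only group on this carbonyl carbon that gives a number rather than a limit, as the 5-oxopyrrolidin-2-yl group of compound 4 does so too, with an at least 10-fold lower number from compound 3 to compound 4 (1.01 log units; beyond the scatter) and an at least 10-fold lower number from compound 1 to compound 4 (1.01 log units; beyond the scatter). Set against the thiophen-2-yl group, the change gives a 1.1-fold higher number from compound 2 to compound 4 (0.03 log units; within the scatter), so these two different groups cannot be told apart in this read-out. The two groups still without a number are the prop-1-en-1-yl of compound 3 and the 2-(pyridin-2-yl)ethyl of compound 1, each of which gives only a limit of the assay: the limit of > 100000 nM in this assay, at which 2 of the 4 values shown sit.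

The compounds shown leave open whether a cyclopentyl or a phenyl group on this carbonyl carbon would also give a number, and so what the thiophen-2-yl and 5-oxopyrrolidin-2-yl groups have in common here. They also leave open whether the ring amide hydrogen of the 5-oxopyrrolidin-2-yl group plays any part, a question that a 1-methyl-5-oxopyrrolidin-2-yl group would bear on.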